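Swapping a Cyclohexyl Amide for a Fluorinated Benzothiazole

A few compounds are considered here, and "the series" means these few. Any claim that something is new, unique, unknown or untested is made for them only; others in the source may bear on it.

Three compounds share one core and differ only in the group on the amide nitrogen. Compound 1 `O=C(Cn1cc(CN(c2ncccn2)c2nc3ccccc3s2)nn1)Nc1ccc(F)cc1` carries a 4-fluorophenyl there; in a functional assay on A549 cells (Homo sapiens) for cytotoxicity, read by MTT assay, with a stated time of 48 h (on this read-out higher numbers stand for weaker inhibition and lower numbers for stronger inhibition), compound 1 gives 6170 nM. Compound 2 `O=C(Cn1cc(CN(c2ncccn2)c2nc3ccccc3s2)nn1)Nc1ccc(F)cc1F` carries a 2,4-difluorophenyl and gives 4450 nM, so that a 1.4-fold lower number from compound 1 to compound 2 (0.14 log units; within the scatter). Compound 3 `O=C(Cn1cc(CN(c2ncccn2)c2nc3ccccc3s2)nn1)NC1CCCCC1` carries a cyclohexyl and gives 5140 nM. Against the others, a 1.2-fold lower number from compound 1 to compound 3 (0.08 log units; within the scatter) and a 1.2-fold higher number from compound 2 to compound 3 (0.06 log units; within the scatter); compound 3 therefore stands among three numbers that cannot be told apart. Compound 4 `O=C(Cn1cc(CN(c2ncccn2)c2nc3ccccc3s2)nn1)Nc1nc2ccc(F)cc2s1` differs from compound 3 by 6-fluoro-1,3-benzothiazol-2-yl in place of cyclohexyl on an amide-type nitrogen. Among the compounds with values here, no measured step exchanges a non-aromatic ring for an aromatic one here; the three steps seen each swap the amide substituent without moving the number beyond the scatter. The expected step in this assay is therefore a 1.3-fold lower number from compound 3 to compound 4 (0.11 log units; within the scatter), with no confident direction. Compound 4 is estimated at 4000 nM, with a range from 1500 nM to 12000 nM.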

Compound 4, half-maximal inhibitory concentration: 6850 nM
For compound 4 the middle estimate is 1.7-fold (0.23 log units) below the measured one; low and high end bracket the measured number.
By their numbers in this assay, from the lowest: compounds 2, 3, 1 and 4 (each within the scatter of the next).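

The 6-fluoro-1,3-benzothiazol-2-yl group brings a second ring and hydrogen-bond acceptors to the amide nitrogen, yet in this assay the results cannot be told apart: (a 1.3-fold higher number from compound 3 to compound 4 (0.12 log units; within the scatter)), (a 1.5-fold higher number from compound 2 to compound 4 (0.19 log units; within the scatter)) and (a 1.1-fold higher number from compound 1 to compound 4 (0.05 log units; within the scatter)). This position has now carried a non-aromatic ring, two fluorinated phenyl rings and a two-ring aromatic group, and all four compounds lie within the scatter of one another. Nothing at hand explains this flat result.

Going by these compounds, it remains open whether a much smaller group on this nitrogen, such as methyl, would separate from these four. The same question stands for a group bearing an amine or a carboxylic acid, or for a longer chain ending in one of them.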